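Smaller aryl group replaces naphthyl in a beta-lactam series

This account rests on a few compounds, and the source may have more. Where it says the series, first, only, none or still open, it means among the compounds named here.

Of the compounds shown here, three sharing a four-membered ring core have been measured in a functional assay on MCF7 cells (Homo sapiens) for antiproliferative activity, read by MTT assay, with stated times of 24 h and 72 h; on this read-out lower numbers stand for stronger inhibition and higher numbers for weaker inhibition. Compound 1 `COc1ccc([C@@H]2[C@H](Oc3ccccc3)C(=O)N2c2cc(OC)c(OC)c(OC)c2)cc1OC` gives 26000 nM, compound 2 `COc1cc(N2C(=O)[C@@H](Oc3ccccc3)[C@H]2c2ccc(Br)cc2)cc(OC)c1OC` gives 48000 nM, and compound 3 `COc1cc(N2C(=O)[C@@H](Oc3ccccc3)[C@H]2c2ccc3ccccc3c2)cc(OC)c1OC` gives 282000 nM. Compound 3 stands highest of the three, that is, it is the weakest inhibitor measured: the step of an 11-fold higher number from compound 1 to compound 3 (1.04 log units; beyond the scatter) is large, and the step of a 5.9-fold higher number from compound 2 to compound 3 (0.77 log units; beyond the scatter) is modest, while the step of a 1.8-fold higher number from compound 1 to compound 2 (0.27 log units; within the scatter) lies within the scatter.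

Compound 4 `COc1cc(N2C(=O)[C@@H](Oc3ccccc3)[C@H]2c2ccc(N)cc2)cc(OC)c1OC` differs from compound 3 in one place: 4-aminophenyl in place of naphthalen-2-yl on a saturated ring carbon. The two steps that bear on this change, from compound 1 and from compound 2 to compound 3, both show that a single six-membered aromatic ring on this saturated ring carbon gives a lower number than naphthalen-2-yl does. Compound 4 carries such a single ring, so a return toward the numbers of compound 1 and compound 2 is expected, with the step of a 7.1-fold lower number from compound 3 to compound 4 (0.85 log units; beyond the scatter) expected in the downward direction. For compound 4 the estimated value in this assay is 40000 nM, within a range from 12000 nM to 150000 nM.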

Compound 4, half-maximal inhibitory concentration: 160000 nM
Compound 4: the middle estimate sits 4.0-fold (0.60 log units) below what was measured; the measured number lies above the stated range.
By their numbers in this assay, from the lowest: compounds 1 and 2 (each within the scatter of the next); then compounds 4 and 3 (each within the scatter of the next).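

In this assay, the change from naphthalen-2-yl to 4-aminophenyl gives a 1.8-fold lower number from compound 3 to compound 4 (0.25 log units; within the scatter), so having a single aromatic ring on this saturated ring carbon is not enough to bring the number back to those of compound 1 and compound 2. What that ring carries also counts: amino in place of bromo gives a 3.3-fold higher number from compound 2 to compound 4 (0.52 log units; beyond the scatter), and 4-aminophenyl in place of 3,4-dimethoxyphenyl gives a 6.2-fold higher number from compound 1 to compound 4 (0.79 log units; beyond the scatter). No measurement is available to explain why amino goes with a higher number here.

The compounds shown leave open whether this higher number is specific to the amino group. A hydroxy, dimethylamino or acetamido group in its place, or an unsubstituted phenyl ring, would help separate the effect of amino from that of losing bromo or the methoxy groups.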